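The compounds below may be only part of what the source reports. "The series", "measured", "known", "first", "only" and "open" are said of these compounds alone.

Compounds measured in an assay on membranes from brain for displacement of a labelled ligand from adenosine receptor A1 (Rattus norvegicus), read by scintillation counting, with a stated time of 90 min; on this read-out higher numbers stand for weaker inhibition and lower numbers for stronger inhibition:
- compound 1, `O=C(CCc1ccccc1)Nc1nc2ccccc2c(=O)s1`, gives 422 nM
- compound 2, `O=C(CCCc1ccccc1)Nc1nc2ccc(Cl)cc2c(=O)s1`, gives a limit of the assay, > 10000 nM
- compound 3, `O=C(CCCc1ccccc1)Nc1nc2ccccc2c(=O)s1`, gives 229 nM

Compound 3 has the lowest number of the two full numbers; the nearest, compound 1, stands within the scatter of it, a 1.8-fold lower number from compound 1 to compound 3 (0.27 log units; within the scatter). For compound 2 the assay gave only a limit, (the limit of > 10000 nM in this assay, at which 1 of the 3 values shown sits). For the measured compounds named here, the only large step known is an at least 43-fold lower number from compound 2 to compound 3 (1.64 log units; beyond the scatter), a change on an aromatic carbon of the shared core.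

Compound 4, `Cc1ccc2nc(NC(=O)CCCc3ccccc3)sc(=O)c2c1`, is not yet measured. Its difference from compound 3 is methyl in place of hydrogen on an aromatic carbon. Going by the values given here, no measured step places a methyl on this ring; the step that bears on it is an at least 43-fold lower number from compound 2 to compound 3 (1.64 log units; beyond the scatter), where a chloro on an aromatic carbon of the core went with a number far beyond the scatter. A methyl is a different group from a chloro, so a weaker effect is expected, but in the same direction, toward a higher number in this assay. Compound 4 is therefore expected to give about 1000 nM, with a range from 300 nM to 5000 nM, which as a step means an expected 4.4-fold higher number from compound 3 to compound 4 (0.64 log units; beyond the scatter).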

Compound 4, inhibition constant: 98.3 nM
Estimate against measurement, compound 4: 10-fold (1.01 log units) above; the whole stated range lies above it.
By their numbers in this assay, from the lowest: compound 4; then compounds 3 and 1 (each within the scatter of the next). At a limit, above all of these: compound 2.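

In this assay, a group on this aromatic carbon of the shared core does not in itself go with a higher number, which compound 2 alone might have suggested: methyl in place of hydrogen gives a 2.3-fold lower number from compound 3 to compound 4 (0.37 log units; beyond the scatter) and so moves the number down, a modest step but one beyond the scatter. The identity of the group on this one carbon therefore decides the direction of the change, as methyl in place of chloro gives an at least 100-fold lower number from compound 2 to compound 4 (2.00 log units; beyond the scatter) in a large step. That step has only a bound, since compound 2 gives a limit and not a number: the limit of > 10000 nM in this assay, at which 1 of the 4 values shown sits.

The compounds shown leave open whether other groups on this carbon, such as methoxy, fluoro or an amine, would follow methyl or chloro, and whether a methyl on the other aromatic carbons of this ring would give a similar step. They also leave open whether the methyl step would hold with the shorter chain of compound 1 or with a longer chain.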